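Sulfonyl substituent variation in a urea-linked activator series

A few compounds are considered here, and "the series" means these few. Any claim that something is new, unique, unknown or untested is made for them only; others in the source may bear on it.

Measured so far:
compound 1 `CN(Cc1ccccc1)S(=O)(=O)c1ccc(NC(=O)NCc2ccncc2)cc1`, 23 nM
compound 2 `O=C(NCc1ccncc1)Nc1ccc(S(=O)(=O)c2ccccc2Cl)cc1`, 79 nM

In an assay on isolated protein for activation of Nicotinamide phosphoribosyltransferase (Homo sapiens) (on this read-out lower numbers stand for an effect already at smaller amounts and higher numbers for an effect only at larger amounts of compound), compound 2 gives 79 nM, the higher of the two numbers recorded so far, while compound 1 gives 23 nM. Among the measured compounds shown here, the only measured step is a 3.4-fold higher number from compound 1 to compound 2 (0.54 log units; beyond the scatter), a modest rise that lies beyond the scatter.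

Compound 3 `O=C(NCc1ccncc1)Nc1ccc(S(=O)(=O)N2CC3CCC(C2)O3)cc1` is not yet measured. It differs from compound 2 by a group of 8 heavy atoms (6 carbon, 1 nitrogen, 1 oxygen; one five-membered non-aromatic ring with 1 hetero atom, one six-membered non-aromatic ring with 2 hetero atoms) in place of a group of 7 heavy atoms (6 carbon, 1 chlorine; one six-membered aromatic ring of carbon only), on a sulfonyl sulfur. The entering group, like the benzyl(methyl)amino group of compound 1, attaches to the sulfonyl sulfur through a nitrogen, whereas the leaving 2-chlorophenyl group attaches through an aromatic carbon. The step of a 3.4-fold higher number from compound 1 to compound 2 (0.54 log units; beyond the scatter) therefore bears on this change, but only in part, since the bicyclic group of compound 3 is not the benzyl(methyl)amino group of compound 1.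

Compound 3 is expected to give a somewhat lower number than compound 2, estimated as a 2.0-fold lower number from compound 2 to compound 3 (0.30 log units; within the scatter). The estimate for compound 3 in this assay is 40 nM, with a range from 12 nM to 150 nM.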

Compound 3, half-maximal effective concentration: 279 nM
Estimate against measurement, compound 3: 7.0-fold (0.84 log units) below; the whole stated range lies below it.
By their numbers in this assay, from the lowest: compound 1; then compound 2; then compound 3.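

In this assay, attachment to the sulfonyl sulfur through a nitrogen does not by itself go with a lower number: compound 1 and compound 3 both attach this way, yet the series shows a 12-fold higher number from compound 1 to compound 3 (1.08 log units; beyond the scatter) for this pair. The group of 8 heavy atoms also compares poorly with the 2-chlorophenyl group, which attaches through an aromatic carbon, with a 3.5-fold higher number from compound 2 to compound 3 (0.55 log units; beyond the scatter), so compound 3 has the highest number of the three and compound 2, with no nitrogen at this attachment, lies nearer to compound 1 than compound 3 does. No available measurement accounts for these differences.

The three compounds leave open whether the lower number of compound 1 depends on the aromatic ring of its benzyl(methyl)amino group, which a benzylamino, dimethylamino or piperidine group on the same sulfonyl sulfur would help to separate. They also leave open how much of the rise in compound 3 belongs to the oxygen of its group rather than to its two-ring carbon framework, a question that a morpholine group alone would only partly address.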